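The source may hold more compounds than are shown below. What is called first, only, known or untested is meant among the compounds shown, and "the series" means these compounds.

In a functional assay on CCRF-CEM cells (Homo sapiens) for antiproliferative activity, read by cell counting, with a stated time of 2 days (a lower number here means a stronger inhibitor, a higher number a weaker inhibitor), two compounds sharing one core have been measured so far. Compound 1 `COc1cc(C(=O)c2sc(N(C)C)nc2N)cc(OC)c1OC` gives 11000 nM, and compound 2 `CCN(CC)c1nc(N)c(C(=O)c2cc(OC)c(OC)c(OC)c2)s1` gives 78000 nM, the higher of the two numbers and so the weaker inhibitor of the pair. Among the measured compounds shown here, the only measured step is a 7.1-fold higher number from compound 1 to compound 2 (0.85 log units; beyond the scatter). This modest step, beyond the scatter, accompanies diethylamino in place of dimethylamino on an aromatic carbon. Compound 3 `CCCCN(C)c1nc(N)c(C(=O)c2cc(OC)c(OC)c(OC)c2)s1` differs from compound 2 at that same place: butyl(methyl)amino in place of diethylamino on an aromatic carbon. For the measured compounds named here, no measured compound carries butyl(methyl)amino, so the single step above is the only guide, and it cannot show how a longer chain paired with a shorter one would compare with diethylamino. In this assay, the expectation is therefore no step beyond the scatter, with a wide margin on either side, since a 7.1-fold higher number from compound 1 to compound 2 (0.85 log units; beyond the scatter) shows that a change at this place can move the number. The expected step is a 1.3-fold lower number from compound 2 to compound 3 (0.11 log units; within the scatter). Compound 3 is estimated at 60000 nM, with an expected range of 18000 nM to 150000 nM.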

Compound 3, half-maximal inhibitory concentration: 42000 nM
For compound 3 the middle estimate is 1.4-fold (0.15 log units) above the measured one, and the stated range covers the measured number.
By their numbers in this assay, from the lowest: compound 1; then compounds 3 and 2 (each within the scatter of the next).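

In this assay, a 1.9-fold lower number from compound 2 to compound 3 (0.27 log units; within the scatter) shows that this place accepts butyl(methyl)amino in place of diethylamino without a step beyond the scatter, so the two groups, with their different chains, cannot be told apart here. The other new step, a 3.8-fold higher number from compound 1 to compound 3 (0.58 log units; beyond the scatter), sets butyl(methyl)amino against dimethylamino and, read with a 7.1-fold higher number from compound 1 to compound 2 (0.85 log units; beyond the scatter), gives a second case in which a larger amino group on this aromatic carbon stands with a higher number than dimethylamino, and none of the three compounds goes against this. Nothing available on these compounds accounts for these differences.

The three compounds leave open whether a free amino group, methylamino or a cyclic amine at this place would give a lower number than compound 1, which stands at 11000 nM. They also leave open whether a longer chain such as dibutylamino would stay level with compound 2 and compound 3 or carry the number higher still.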